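The compounds below may be only part of what the source reports. "The series", "measured", "known", "first", "only" and "open" are said of these compounds alone.

Series values in a functional assay on MV4-11 cells (Homo sapiens) for antiproliferative activity, read by CCK-8 assay, with a stated time of 72 h; on this read-out lower numbers stand for stronger inhibition and higher numbers for weaker inhibition:

- compound 1 `Cc1cc(F)cc(C)c1Oc1ccc(C(C)(C)O)cc1-c1cn(C)c(=O)c2[nH]c(C(=O)NCc3ccc(C(=O)NO)cc3)cc12` gives 440 nM
- compound 2 `Cn1cc(-c2ccccc2Oc2ccccc2)c2cc(C(=O)NCc3ccc(C(=O)Nc4ccccc4N)cc3)[nH]c2c1=O` gives 80 nM
- compound 3 `Cn1cc(-c2ccccc2)c2cc(C(=O)NCc3ccc(C(=O)Nc4ccccc4N)cc3)[nH]c2c1=O` gives 230 nM

In this assay compound 3 lies within the scatter of compound 1 and well clear of compound 2 on the weaker side. The next compound to be read is compound 4 `Cn1cc(-c2ccc(F)cc2)c2cc(C(=O)NCc3ccc(C(=O)Nc4ccccc4N)cc3)[nH]c2c1=O`, which has fluoro in place of hydrogen on an aromatic carbon, para to a large group (fluoro in place of hydrogen on an aromatic carbon).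

Within the data shown here, only one measured step bears on this change. It is the exchange of phenoxy for hydrogen on an aromatic carbon, a 2.9-fold higher number from compound 2 to compound 3 (0.46 log units; beyond the scatter), a modest step. Among the measured compounds shown here, that step involves a different group, so it gives only a rough upper guide to what a single fluoro might do, and no measured step covers fluoro itself. No step beyond the scatter is therefore expected, in either direction. The expected change is a 1.2-fold lower number from compound 3 to compound 4 (0.06 log units; within the scatter). For compound 4 the estimated value is 200 nM, with an expected range of 90 nM to 450 nM.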

Compound 4, half-maximal inhibitory concentration: 220 nM
Beside the measured number, compound 4's estimate is 1.1-fold (0.04 log units) below it; low and high end bracket the measured number.
By their numbers in this assay, from the lowest: compound 2; then compounds 4, 3 and 1 (each within the scatter of the next).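

In this assay, fluoro in place of hydrogen on this aromatic carbon, para to a large group, gives a 1.0-fold lower number from compound 3 to compound 4 (0.02 log units; within the scatter), so the phenyl to 4-fluorophenyl change leaves the antiproliferative reading unmoved. Among these compounds, the only step beyond the scatter in this set remains a 2.9-fold higher number from compound 2 to compound 3 (0.46 log units; beyond the scatter), and a single fluoro does not produce a step of that kind. No measurement on hand bears on why the reading stays flat at this position.

Still open, from the compounds shown here alone, is whether a group larger than fluoro at this same place, such as methoxy, trifluoromethyl or a dimethylamino group, would give a step beyond the scatter. Also open, going by these compounds, is whether fluoro would remain equally silent on the phenoxy-bearing compound 2, where the starting number is lower.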